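Amide variation on two pyridine-linked cores

The source may hold more compounds than are shown below. What is called first, only, known or untested is meant among the compounds shown, and "the series" means these compounds.

Compound 2 `O=C(/C=C/c1ccncc1-c1ccc2cc[nH]c2c1)N1CCOCC1` and compound 1 `CNC(=O)/C=C/c1ccncc1-c1ccc2cc[nH]c2c1` share a core and differ only in the amide. In a functional assay on MCF7 cells (Homo sapiens) for inhibition, read by sulforhodamine B assay, with a stated time of 72 h (a lower number here means a stronger inhibitor of growth, a higher number a weaker inhibitor of growth), compound 2 reaches only the limit of the method, > 10000 nM. In this assay compound 1 gives 9230 nM. The step is an at least 1.0-fold lower number from compound 2 to compound 1 (0.03 log units; that floor lies within the scatter), with the change (methylamino in place of morpholin-4-yl on a carbonyl carbon). The size of that step is bounded because the limit of > 10000 nM in this assay, at which 2 of the 3 values shown sit, sits at the top of the range read.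

Compound 3 `O=C(CCc1ccncc1-c1ccc2ccccc2c1)N1CCOCC1` carries a different core; the difference between the two cores is not broken down here. In this assay compound 3 also returns only a limit, > 10000 nM.

Compound 4 `CNC(=O)CCc1ccncc1-c1ccc2ccccc2c1` is yet to be measured in this assay. Its relation to compound 3 is methylamino in place of morpholin-4-yl on a carbonyl carbon. This is the same kind of change as from compound 2 to compound 1, but the place differs: in compound 2 the carbonyl carbon's other neighbour is a double-bonded chain carbon, in compound 3 it is a saturated chain carbon.

The expected step from compound 3 to compound 4 is a step that the limit leaves unreadable from compound 3 to compound 4, resting on the small and bounded step an at least 1.0-fold lower number from compound 2 to compound 1 (0.03 log units; that floor lies within the scatter) and on compound 3 sitting at a limit, > 10000 nM. For compound 4 the estimate in this assay is 12000 nM, expected between 4000 nM and 30000 nM, with a real chance that only a limit is reported again.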

Compound 4, concentration for 50% growth inhibition: > 10000 nM
Compound 4: only a limit was reported (the forecaster's own chance of this, stated with the estimate: 60%); the middle value lies beyond the limit too.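

Compound 3 and compound 4 each return only a limit in this assay, and no step can be read between the two limits: the limit of > 10000 nM in this assay, at which 3 of the 4 values shown sit.

The compounds shown leave open how far methylamino in place of morpholin-4-yl on a carbonyl carbon shifts growth inhibition when the carbonyl carbon's other neighbour is a saturated chain carbon, and whether that shift matches the one from compound 2 to compound 1.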